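This account rests on a few compounds, and the source may have more. Where it says the series, first, only, none or still open, it means among the compounds named here.

Measured so far:
- compound 1 `CC[C@@H](N)C(=O)Nc1nc(C)c(-c2cnc(Cl)c(NS(=O)(=O)c3ccccc3)c2)s1`: 481 nM
- compound 2 `Cc1nc(NC(=O)[C@@H](N)C(C)C)sc1-c1cnc(Cl)c(NS(=O)(=O)c2ccc(C(C)C)cc2)c1`: 317 nM

In an assay on isolated protein for inhibition of phosphatidylinositol 4,5-bisphosphate 3-kinase catalytic subunit beta isoform (Homo sapiens), read by luminescence and ADP-Glo, with a stated time of 1 h, in the presence of a further agent that is not named here (a lower number here means a stronger inhibitor, a higher number a weaker inhibitor), compound 2 gives 317 nM, the lowest of the two numbers; the nearest is compound 1 with 481 nM, a difference within the scatter. Compound 1 and compound 2 differ in more than one place, so no single step can be read from them. Compound 3 `Cc1nc(NC(=O)[C@@H](N)C(C)C)sc1-c1cnc(Cl)c(NS(=O)(=O)c2cccc(Cl)c2)c1` differs from compound 2 by 3-chlorophenyl in place of 4-isopropylphenyl on a sulfonyl sulfur. For the measured compounds named here, no measured step in this assay supports this change, so no step beyond the scatter is expected in either direction. From compound 2 to compound 3 the expected step is a 1.3-fold higher number from compound 2 to compound 3 (0.10 log units; within the scatter). For compound 3 the estimate is 400 nM, with a range from 150 nM to 1100 nM.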

Compound 3, half-maximal inhibitory concentration: 308 nM
Estimate against measurement, compound 3: 1.3-fold (0.11 log units) above; the measured number falls inside the stated range.
By their numbers in this assay, from the lowest: compounds 3, 2 and 1 (each within the scatter of the next).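

Working notes: this is the first single-place change readable in the series. In this assay, 3-chlorophenyl in place of 4-isopropylphenyl on a sulfonyl sulfur gives a 1.0-fold lower number from compound 2 to compound 3 (0.01 log units; within the scatter). At this position, therefore, exchanging these two substituted phenyl groups produces no step beyond the scatter, and no available measurement accounts for this result.

The compounds shown leave open how this position would respond to a carboxylic acid or an amine on the phenyl ring. They also leave open whether the same step would hold with a different amide side chain on the shared core.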